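The source may hold more compounds than are shown below. What is called first, only, known or untested is meant among the compounds shown, and "the series" means these compounds.

Measured so far in a functional assay on FM3A cells (Mus musculus) for antiproliferative activity, read by cell counting, with a stated time of 2 days; a lower number here means a stronger inhibitor, a higher number a weaker inhibitor:
compound 1 `COc1ccc(C(=O)c2sc(Nc3ccc(Cl)cc3)nc2N)cc1`: > 10000 nM (a limit)
compound 2 `Nc1nc(Nc2ccc(Cl)cc2)sc1C(=O)c1ccccc1`: > 10000 nM (a limit)
compound 3 `COc1ccccc1C(=O)c1sc(Nc2ccccc2)nc1N`: 1100 nM

In this assay compound 1 gives only a limit, > 10000 nM, so it offers no number to start from. Compound 1 stands at the limit of > 10000 nM in this assay, at which 2 of the 3 values shown sit. Compound 4 `COc1ccc(C(=O)c2sc(Nc3ccc(F)cc3)nc2N)cc1` keeps the core of compound 1 and makes one change: fluoro in place of chloro on an aromatic carbon. This places fluoro in place of chloro on an aromatic carbon, para to a large group, turning the 4-chlorophenyl into a 4-fluorophenyl.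

For the measured compounds named here, the only measured single change is a step that the two limits leave unreadable from compound 1 to compound 2. That change puts hydrogen in place of methoxy and leaves the chloro untouched, so it gives no size to carry over. Compound 3 does reach a number, 1100 nM, but no single change links it to compound 1. Going by the values given here, no measured step exchanges the chloro. The expectation in this assay is therefore no step beyond the scatter, with only a slight leaning towards a lower number. The expected change is a number no higher from compound 1 to compound 4 (the limit leaves the size open). Compound 4 may well be reported only as a limit again. For compound 4 the estimate is 10000 nM, with an expected range from 3000 nM to 30000 nM.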

Compound 4, half-maximal inhibitory concentration: > 10000 nM
Compound 4 ended at the assay's limit (the forecaster's own chance of this, stated with the estimate: 60%); the middle value sits exactly at the limit.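

In this assay compound 4 gives > 10000 nM, a limit and not a number. Compound 1 likewise gives only a limit, > 10000 nM. For the compounds shown here, no step can therefore be read between compound 1 and compound 4. The compounds shown leave open whether fluoro and chloro differ at all in their effect on this core.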